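A few compounds are considered here, and "the series" means these few. Any claim that something is new, unique, unknown or untested is made for them only; others in the source may bear on it.

Measured so far:
compound 1, `C/C(C#Cc1ccccc1)=N\N/C(N)=N/S(=O)(=O)c1cc(C)c(Cl)cc1SCc1ccccc1`, 6000 nM
compound 2, `C/C(C#Cc1ccccc1)=N\N/C(N)=N/S(=O)(=O)c1cc(C)c(Cl)cc1SCc1cccc(C)c1`, 105000 nM
compound 3, `C/C(C#Cc1ccccc1)=N\N/C(N)=N/S(=O)(=O)c1cc(C)c(Cl)cc1SCc1ccc(C(F)(F)F)cc1`, 8000 nM

In a functional assay on HeLa cells (Homo sapiens) for antiproliferative activity, read by MTT assay, with a stated time of 72 h (on this read-out higher numbers stand for weaker inhibition and lower numbers for stronger inhibition), compound 3 stands second highest of the three numbers; it sits close to compound 1, with a 1.3-fold higher number from compound 1 to compound 3 (0.12 log units; within the scatter) lying within the scatter, and far from compound 2, with a 13-fold lower number from compound 2 to compound 3 (1.12 log units; beyond the scatter) a large step. Compound 4, `C/C(C#Cc1ccccc1)=N\N/C(N)=N/S(=O)(=O)c1cc(C)c(Cl)cc1SCc1cccc(Cl)c1`, has not been measured. It differs from compound 3 in one place: 3-chlorophenyl in place of 4-(trifluoromethyl)phenyl on a saturated chain carbon bound to a sulfur. Within the data shown here, two measured steps bear on this. From compound 1 to compound 2 a methyl placed on the ring gave an 18-fold higher number from compound 1 to compound 2 (1.24 log units; beyond the scatter), a large loss, while the trifluoromethyl of compound 3 left the number essentially where compound 1 stands. Compound 4 carries chlorine at the same ring position as the methyl of compound 2, so a weakening beyond the scatter is expected, though chlorine and methyl are not the same group and the size is uncertain. For compound 4 the expected step is a 3.8-fold higher number from compound 3 to compound 4 (0.57 log units; beyond the scatter), giving an estimate of 30000 nM with a range from 7000 nM to 150000 nM.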

Compound 4, half-maximal inhibitory concentration: 21000 nM
Estimate against measurement, compound 4: 1.4-fold (0.15 log units) above; the measured number falls inside the stated range.
By their numbers in this assay, from the lowest: compounds 1 and 3 (each within the scatter of the next); then compound 4; then compound 2.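

In this assay, chloro on the benzyl ring gives a 3.5-fold higher number from compound 1 to compound 4 (0.54 log units; beyond the scatter), so methyl is no longer the only group shown to weaken the number at this place. The kind of group also matters, as chloro in place of methyl gives a 5.0-fold lower number from compound 2 to compound 4 (0.70 log units; beyond the scatter), recovering part of the large loss seen with compound 2 without returning to the level of compound 1. The change from 4-(trifluoromethyl)phenyl to 3-chlorophenyl gives a 2.6-fold higher number from compound 3 to compound 4 (0.42 log units; beyond the scatter), but no measurement shown here explains any of these steps.

That last change alters both the group and its place on the ring, and these compounds cannot separate the two. As far as these compounds go, how a ring carrying an amine or a carboxylic acid would behave at this place also remains open.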